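The source may report more compounds than this note shows. Statements on the series, on what has been measured and on what is new or still open speak of the compounds shown alone.

Measured so far:
Compound 1, `CC(C)(C)OC(=O)Nc1cccc(-c2ccc(C(=O)N[C@@H](CCCN=C(N)N)B3O[C@@H]4CC5CC(C5(C)C)[C@]4(C)O3)o2)c1`, in an assay on isolated protein for inhibition of serine protease 1 (Homo sapiens) (on this read-out higher numbers stand for weaker inhibition and lower numbers for stronger inhibition), gives 25 nM.
Compound 2, `COC(=O)NS(=O)(=O)c1ccccc1-c1ccc(C(=O)N[C@@H](CCCN=C(N)N)B2O[C@@H]3CC4CC(C4(C)C)[C@]3(C)O2)c(C)c1`, in this assay gives 0.64 nM.

Compound 2 has the lowest of the two numbers, and the gap from it to compound 1 lies beyond the scatter. Compound 3, `CCN(CC)S(=O)(=O)c1ccccc1-c1ccc(C(=O)N[C@@H](CCCN=C(N)N)B2O[C@@H]3CC4CC(C4(C)C)[C@]3(C)O2)c(C)c1`, has not been measured. It differs from compound 2 in one place: diethylamino in place of (methoxycarbonyl)amino on a sulfonyl sulfur. Within the data shown here, no measured pair carries this change, so the expectation rests on the two values alone. In this assay the step is expected to be a weakening beyond the scatter, a 13-fold higher number from compound 2 to compound 3 (1.10 log units; beyond the scatter). Compound 3 is estimated at 8 nM, with a range from 1.5 nM to 50 nM.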

Compound 3, inhibition constant: 0.62 nM
Compound 3: the middle estimate sits 13-fold (1.11 log units) above what was measured; measured number outside the range, below it.
By their numbers in this assay, from the lowest: compounds 3 and 2 (each within the scatter of the next); then compound 1.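

In this assay, diethylamino in place of (methoxycarbonyl)amino on a sulfonyl sulfur gives a 1.0-fold lower number from compound 2 to compound 3 (0.01 log units; within the scatter). This place therefore accepts the change with no shift beyond the scatter, even though the hydrogen-bond donor and hydrogen-bond acceptors counted on (methoxycarbonyl)amino are absent from diethylamino. No evidence on hand bears on why the two compounds match. Going by these compounds, whether dimethylamino, a piperidine ring joined through its nitrogen, or a plain amino group on the same sulfonyl sulfur would also stay within the scatter of compound 2 in this assay remains open.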